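The source may report more compounds than this note shows. Statements on the series, on what has been measured and on what is new or still open speak of the compounds shown alone.

Series notes. Compound 1 `C=CC1=C(C(=O)NCCC)C(c2ccc(F)cc2)OC1` and compound 2 `C=CC1=C(C(=O)NCc2ccc(C)cc2)C(c2ccc(F)cc2)OC1` share one core and differ only in the group on the amide nitrogen. In a functional assay on QGY7701 cells (Homo sapiens) for cytotoxicity, read by MTT assay, with a stated time of 24 h (a lower number here means a stronger inhibitor, a higher number a weaker inhibitor), compound 1 reports only a limit of the assay, > 100000 nM. In this assay compound 2 gives 62100 nM. From the compounds shown here alone, the step of an at least 1.6-fold lower number from compound 1 to compound 2 (0.20 log units; that floor lies within the scatter) is anchored by the limit of > 100000 nM in this assay, at which 1 of the 2 values shown sits, so its true size stays open. Compound 3 `C=CC1=C(C(=O)O)C(c2ccc(F)cc2)OC1` carries the acid in place of the amide of compound 1: hydroxy in place of propylamino on a carbonyl carbon. Among the measured compounds shown here, no measured step exchanges an amide for an acid; the only step measured, from compound 1 to compound 2, alters the amide substituent alone and is bounded by the limit of > 100000 nM in this assay, at which 1 of the 2 values shown sits, so it does not bear directly on this change. For compound 3 the expected step is a number no higher from compound 1 to compound 3 (the limit leaves the size open), with the read-out likely to sit again at the limit. Compound 3 is expected near 100000 nM, within a range from 30000 nM to 300000 nM in this assay.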

Compound 3, half-maximal inhibitory concentration: > 100000 nM
Compound 3: a limit, no number (the forecaster's own chance of this, stated with the estimate: 60%); the middle value sits exactly at the limit.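

Compound 1 and compound 3 both stop at a limit of the assay, so no step between them can be read: the limit of > 100000 nM in this assay, at which 2 of the 3 values shown sit.

Still open, from the compounds shown here alone, is whether hydroxy in place of propylamino on a carbonyl carbon changes the read-out at all, and how far the true values of compound 1 and compound 3 lie from that limit.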